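Cyano to Nitro in a Small Cytotoxicity Series

The compounds below may be only part of what the source reports. "The series", "measured", "known", "first", "only" and "open" are said of these compounds alone.

Of the compounds shown here, two sharing one core have been measured so far in a functional assay on HeLa cells (Homo sapiens) for cytotoxicity, read by MTT assay, with a stated time of 48 h; on this read-out lower numbers stand for stronger inhibition and higher numbers for weaker inhibition. For compound 1 (`O=C(O)CN1C(=O)/C(=C/c2nc3ccccc3n2Cc2ccc(Br)cc2F)SC1=S`) the result is > 50000 nM, which is a limit of the test and not a number. Among the measured compounds shown here, compound 2 (`N#Cc1ccc(Cn2c(/C=C3\SC(=S)N(CC(=O)O)C3=O)nc3ccccc32)cc1`) gives 16300 nM, the only true number available, so it is the single firm reference point. For the measured compounds named here, putting 4-cyanophenyl in place of 4-bromo-2-fluorophenyl is the one measured step, an at least 3.0-fold lower number from compound 1 to compound 2 (0.48 log units; beyond the scatter), and it lies beyond the scatter.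

Compound 3 (`O=C(O)CN1C(=O)/C(=C/c2nc3ccccc3n2Cc2ccc([N+](=O)[O-])cc2)SC1=S`) brings a new change: nitro in place of cyano on an aromatic carbon. In words, this is nitro in place of cyano on an aromatic carbon, para to a large group. Going by the values given here, only the step above bears on it, since it also swapped the substituted phenyl group and shows that this assay can respond to such a swap. Among the compounds with values here, no measured step exchanges these two groups, however, so the data give no direction. The expected step is a 1.1-fold higher number from compound 2 to compound 3 (0.04 log units; within the scatter), which means no change beyond the scatter is expected. The estimate for compound 3 is 18000 nM, with an expected range of 7000 nM to 45000 nM.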

Compound 3, half-maximal inhibitory concentration: 18600 nM
The estimate for compound 3 lay 1.0-fold (0.01 log units) below the measured number; low and high end bracket the measured number.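

In this assay, the exchange of cyano for nitro on this aromatic carbon gives a 1.1-fold higher number from compound 2 to compound 3 (0.06 log units; within the scatter), so at this position the two groups cannot be told apart by this read-out, even though they differ in their atoms and in their hydrogen-bond acceptor counts. The other new step reads an at least 2.6-fold lower number from compound 1 to compound 3 (0.42 log units; beyond the scatter), which means that 4-nitrophenyl, like 4-cyanophenyl before it, lies beyond the scatter from 4-bromo-2-fluorophenyl, and a second group now supports the earlier step. The size of that step remains only a lower bound, because compound 1 gives a limit of the test and not a number: the limit of > 50000 nM in this assay, at which 1 of the 3 values shown sits.

The compounds shown leave open whether other groups at this same place, such as an amine or a methoxy group, would also leave the number unchanged, or whether the flat result holds only for cyano and nitro. They also cannot separate the roles of the bromine and the fluorine in compound 1, since the two leave together in each step, and a plain phenyl ring would be needed as a reference.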